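A few compounds are considered here, and "the series" means these few. Any claim that something is new, unique, unknown or untested is made for them only; others in the source may bear on it.

Measured compounds:
- Compound 1, `COc1ncc(C2CCCC2)cc1CO[C@H]1[C@H](C(C)(C)C)[C@@H](C(=O)O)N(C(=O)C2CCCCC2)[C@H]1c1ccccc1`: in an assay on cells with Cystic fibrosis transmembrane conductance regulator variant F508del (Homo sapiens) as the target, read by voltage clamp, with a stated time of 24 h, in the presence of a further agent that is not named here (a higher number here means a larger maximal response, a lower number a smaller maximal response), compound 1 gives 203%
- Compound 2, `COc1ncc(C(F)(F)F)cc1CO[C@H]1[C@H](C(C)(C)C)[C@@H](C(=O)O)N(C(=O)[C@H]2CCCCO2)[C@H]1c1ccccc1`: in this assay compound 2 gives 351%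
- Compound 3, `COc1ncc(C(F)(F)F)cc1CO[C@H]1[C@H](C(C)(C)C)[C@@H](C(=O)O)N(C(=O)[C@@H]2CCCCO2)[C@H]1c1ccccc1C(C)C`: in this assay compound 3 gives 570%

Among these three, compound 3 gives the largest maximal response. Its nearest neighbour is compound 2, and the gap between them lies beyond the usual scatter of this kind of measurement; compound 1 lies further away still, also beyond the scatter. Compound 2 and compound 3 differ in more than one place, so their two values can only be set side by side, not read as a single step.

The next compound, compound 4, `COc1ncc(C(F)(F)F)cc1CO[C@H]1[C@H](C(C)(C)C)[C@@H](C(=O)O)N(C(=O)[C@@H]2CCCCO2)[C@H]1c1ccccc1Cl`, is not yet measured. It differs from compound 3 in one place:

chloro in place of isopropyl on an aromatic carbon

Going by the values given here, since no single-point step between measured compounds is available, the expectation for compound 4 rests on the fact that compound 3 gives 570% while compound 2, which carries no group at that position, gives a lower number. A modest decrease in this assay, of a size expected as a number 90 percentage points lower from compound 3 to compound 4 (beyond the scatter), seems plausible. Compound 4 is therefore estimated at 480%, with a range from 330% to 650%.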

Compound 4, largest response reached (Emax), in percent of the reference or control that the assay uses: 694%
Estimate against measurement, compound 4: 214 percentage points below; measured number above the stated range.
By their numbers in this assay, from the lowest: compound 1; then compound 2; then compound 3; then compound 4.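

Replacing isopropyl with chloro on this aromatic carbon, ortho to a large group, gives a number 124 percentage points higher from compound 3 to compound 4 (beyond the scatter) in this assay. Going by these compounds alone, this is the first single-change comparison, and it shows that the maximal response is sensitive to the group at this position. It also shows that the three-carbon isopropyl group is not required for a high response, since chloro, with one heavy atom, gives the higher number. Nothing available here explains why this exchange raises the response.

Still open, from the compounds shown here alone, is how a methyl, a fluoro, a methoxy or a nitrile group would read at the same position, and so whether the gain is specific to chloro. Going by these compounds, it is also open whether the same exchange would give a similar step on a core carrying a different amide group.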